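Swapping phenyl for butyl on a weak amide

A few compounds are considered here, and "the series" means these few. Any claim that something is new, unique, unknown or untested is made for them only; others in the source may bear on it.

Values so far in a functional assay (brain) for inhibition, with Rattus norvegicus as the target; a lower number here means a stronger inhibitor, a higher number a weaker inhibitor:
Compound 1 `COc1cc2c(cc1O)CCC(C(=O)Nc1ccccc1)O2` gives 6900 nM
Compound 2 `COc1cc2c(cc1O)C(=O)CC(C(=O)O)O2` gives > 300000 nM
Compound 3 `COc1cc2c(cc1O)C(=O)CC(C(=O)Nc1ccccc1)O2` gives 293000 nM

Compound 2 has the entry > 300000 nM, which is a limit of the assay and not a number. Of the two true numbers, compound 3 has the higher, which makes it a weak inhibitor, while compound 1 reads lower (6900 nM).

Compound 4 `CCCCNC(=O)C1CC(=O)c2cc(O)c(OC)cc2O1` differs from compound 3 by a single change (butyl in place of phenyl on an amide-type nitrogen), with butyl in place of phenyl on an amide-type nitrogen. Among the measured compounds shown here, only one measured step touches this amide, namely an at least 1.0-fold lower number from compound 2 to compound 3 (0.01 log units; that floor lies within the scatter), which puts anilino in place of hydroxy on a carbonyl carbon. That step starts from a limit and stays within the scatter, so it gives no size for the new change. For the measured compounds named here, no measured step swaps one group on that nitrogen for another.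

The starting point for an expectation is therefore compound 3 (293000 nM), and no step beyond the scatter is expected in this assay in either direction. The expected change is a 1.5-fold lower number from compound 3 to compound 4 (0.17 log units; within the scatter), a small one. Compound 4 is estimated at about 200000 nM, within an expected range (60000 nM to 500000 nM). A report of only a limit would be no surprise.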

Compound 4, half-maximal inhibitory concentration: 177000 nM
For compound 4 the middle estimate is 1.1-fold (0.05 log units) above the measured one, and the stated range covers the measured number.
By their numbers in this assay, from the lowest: compound 1; then compounds 4 and 3 (each within the scatter of the next). At a limit, above all of these: compound 2.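

Among the compounds shown here, this is the first measured swap of one group for another on the amide-type nitrogen. In this assay, replacing the phenyl ring with an open butyl chain gives a 1.7-fold lower number from compound 3 to compound 4 (0.22 log units; within the scatter), so the two groups cannot be told apart at this position, and this assay shows no need for an aromatic ring on that nitrogen. The other new step, an at least 1.6-fold lower number from compound 2 to compound 4 (0.22 log units; that floor lies within the scatter), starts from a limit of the assay and not a number, so it sets only a floor and gives no size for the change from hydroxy to butylamino.

Going by these compounds, what remains open is whether any group on this nitrogen can move the number beyond the scatter, for example a longer chain, a benzyl group, or a butyl chain ending in an amine or a carboxylic acid. The compounds shown also leave open whether butyl and phenyl would still read alike on the core of compound 1, which carries the anilino group and gives 6900 nM in this assay.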